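This account rests on a few compounds, and the source may have more. Where it says the series, first, only, none or still open, it means among the compounds named here.

Of the compounds shown here, three built on a shared core have been tested in an ADME assay on microsomes from liver (Homo sapiens) for metabolic stability, with a stated time of 10 min, tested at 0.5 uM; on this read-out higher numbers stand for a more stable compound and lower numbers for a less stable compound. In this test, compound 1 (`COc1ncc(NC(=O)[C@H](C)[C@H]2CC[C@@H](c3ccnc4ccc(F)cc43)CC2)cn1`) gives 73%, compound 2 (`C[C@@H](CNc1ccc(Cl)cc1)[C@H]1CC[C@@H](c2ccnc3ccc(F)cc32)CC1`) gives 80% and compound 3 (`C[C@@H](NC(=O)Nc1ccc(Cl)cc1)[C@H]1CC[C@@H](c2ccnc3ccc(F)cc32)CC1`) gives 52%. Compound 3 is therefore the lowest of the three, and both gaps lie beyond the scatter. Compound 4 (`C[C@@H](NC(=O)C12CCC(Cl)(CC1)CC2)[C@H]1CC[C@@H](c2ccnc3ccc(F)cc32)CC1`) alters compound 3 on a carbonyl carbon: a group of 9 heavy atoms (8 carbon, 1 chlorine; 2 six-membered non-aromatic rings of carbon only) in place of a group of 8 heavy atoms (6 carbon, 1 nitrogen, 1 chlorine; one six-membered aromatic ring of carbon only), on a carbonyl carbon. Among the compounds with values here, no measured pair differs in one place only, so the size of this change has no direct precedent. Since compound 3 sits at the bottom of a small set, with compound 1 at 73%, a modest rise is expected, estimated as a number 13 percentage points higher from compound 3 to compound 4 (beyond the scatter). The estimate for compound 4 is 65%, within a range from 42% to 86%.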

Compound 4, percent of the compound remaining: 9%
Beside the measured number, compound 4's estimate is 56 percentage points above it, outside the stated range (below it).
By their numbers in this assay, from the lowest: compound 4; then compound 3; then compounds 1 and 2 (each within the scatter of the next).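

The group on the carbonyl carbon strongly affects the result in this assay: replacing (4-chlorophenyl)amino with the chlorine-bearing group of 2 six-membered non-aromatic carbon rings gives a number 43 percentage points lower from compound 3 to compound 4 (beyond the scatter). Within the data shown here, this is the first measured step at this place, and it shows that the two groups are far from interchangeable here. No available evidence explains the drop. The change removes the aromatic ring and the hydrogen-bond donor together, so their contributions remain unseparated. Going by these compounds, how a plain cyclohexyl group or a carboxylic acid would behave at this place remains open.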